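Swapping a Methylphenyl for a Methyloxazolyl Amide

The source may hold more compounds than are shown below. What is called first, only, known or untested is meant among the compounds shown, and "the series" means these compounds.

Three compounds sharing one core were tested in an assay on isolated protein for inhibition of Rho-associated protein kinase 2 (Homo sapiens), read by scintillation counting, radiometric assay and 33P incorporation, with a stated time of 40 min, in the presence of a further agent that is not named here; on this read-out lower numbers stand for stronger inhibition and higher numbers for weaker inhibition. Compound 1 `COc1cccc(OCC(=O)Nc2cccc(NC(=O)c3ccc(N(C)C)cc3)c2)c1` gives 5740 nM in this assay. Compound 2 `CN(C)c1ccc(C(=O)Nc2cccc(NC(=O)COc3ccc4occc(=O)c4c3)c2)cc1` gives only a limit, > 10000 nM, in this assay; this is the limit of > 10000 nM in this assay, at which 1 of the 3 values shown sits. The step of an at least 1.7-fold higher number from compound 1 to compound 2 (0.24 log units; that floor lies within the scatter) changes the group on an oxygen on a saturated carbon. Compound 3 `Cc1ccc(C(=O)Nc2cccc(NC(=O)COc3ccc4c(=O)ccoc4c3)c2)cc1` gives 22 nM in this assay, the lowest of the two numbers shown; the nearest number, that of compound 1, lies far higher, well beyond the usual scatter.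

Compound 4 `Cc1cc(C(=O)Nc2cccc(NC(=O)COc3ccc4c(=O)ccoc4c3)c2)no1` has not been measured. It differs from compound 3 by 5-methyl-1,2-oxazol-3-yl in place of 4-methylphenyl on a carbonyl carbon. No measured step touches the group on this carbonyl carbon: the single step shown, between compound 1 and compound 2, sits on the other side of the core, on the ether oxygen, so the data give no direct guide to the size of this change. Among the measured compounds shown here, with no step to lean on, a moderate weakening beyond the scatter is expected, since a five-membered aromatic ring with two hetero atoms replaces a six-membered aromatic ring of carbon only. Compound 4 is therefore estimated at 80 nM, with a range from 15 nM to 400 nM. The expected step is a 3.6-fold higher number from compound 3 to compound 4 (0.56 log units; beyond the scatter).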

Compound 4, half-maximal inhibitory concentration: 5 nM
For compound 4 the middle estimate is 16-fold (1.20 log units) above the measured one; measured number below the stated range.
By their numbers in this assay, from the lowest: compound 4; then compound 3; then compound 1. At a limit, above all of these: compound 2.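

Replacing 4-methylphenyl with 5-methyl-1,2-oxazol-3-yl on this carbonyl carbon gives a 4.4-fold lower number from compound 3 to compound 4 (0.64 log units; beyond the scatter) in this assay, the only step shown at this place on the shared core. The earlier step, from compound 1 to compound 2, sat on the other side of the core and said nothing about this place. The new step shows that a six-membered aromatic ring of carbon only can give way here to the five-membered aromatic ring of 5-methyl-1,2-oxazol-3-yl, bringing 2 hydrogen-bond acceptors where the departing group has none, with a modest gain rather than a loss; nothing shown here explains why the number falls.

On these data alone, a single pair of compounds stands behind this, so it remains open whether the same swap would act the same way with a different group on the ether oxygen. Also open, as far as these compounds go, is what this place would give with the methyl on the 1,2-oxazole replaced by a hydrogen, an amine or a carboxylic acid, and thus whether that methyl matters at all.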